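Varying the benzyl group: from chloro to dimethyl

The compounds below may be only part of what the source reports. "The series", "measured", "known", "first", "only" and "open" are said of these compounds alone.

Within the data shown here, compound 1 `COc1cc(N)c(Cl)cc1NC(=O)C1CCN(Cc2ccc(Cl)cc2)CC1` is the one member of the series with a number in a functional assay on the whole organism for antagonist activity, with Mus musculus as the target (a higher number here means that more compound is needed for the effect, a lower number that less compound is needed), where compound 1 gives 1.2 mg/kg. Compound 2 `COc1cc(N)c(Cl)cc1NC(=O)C1CCN(Cc2ccc([N+](=O)[O-])cc2)CC1` reaches only the limit of the assay, > 4 mg/kg. Compound 3 `COc1cccc(CN2CCC(C(=O)Nc3cc(Cl)c(N)cc3OC)CC2)c1` likewise stops at the limit, > 4 mg/kg. Two steps out of compound 1 are therefore known only in one direction: an at least 3.3-fold higher number from compound 1 to compound 2 (0.52 log units; beyond the scatter), and an at least 3.3-fold higher number from compound 1 to compound 3 (0.52 log units; beyond the scatter); both rest on (the limit of > 4 mg/kg in this assay, at which 2 of the 3 values shown sit). Compound 4 `COc1cc(N)c(Cl)cc1NC(=O)C1CCN(Cc2ccc(C)c(C)c2)CC1` has not yet been measured in this assay; it differs from compound 1 in one place: 3,4-dimethylphenyl in place of 4-chlorophenyl on a saturated chain carbon bound to an amine nitrogen in a ring. Both measured steps away from the 4-chlorophenyl of compound 1 gave a higher number in this assay beyond the scatter, so a higher number is expected for compound 4 as well; both measured steps are known only as limits, and the size of the step is open. The estimate for compound 4 in this assay is 3 mg/kg, within 1.2 mg/kg to 8 mg/kg, which corresponds to an expected step of a 2.5-fold higher number from compound 1 to compound 4 (0.40 log units; beyond the scatter).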

Compound 4, dose for half-maximal effect: > 8 mg/kg
Compound 4 gave a limit, no number; the forecaster's own chance of this, stated with the estimate: 40%; middle value at least 2.6-fold (0.42 log units) from the limit.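

The 3,4-dimethylphenyl group on the saturated chain carbon gives an at least 6.6-fold higher number from compound 1 to compound 4 (0.82 log units; beyond the scatter) in this assay, so the loss now also appears with a replacement that, like 4-chlorophenyl, has 0 hydrogen-bond donors and 0 hydrogen-bond acceptors, unlike the nitro and methoxy replacements before it. All three replacements of 4-chlorophenyl shown give a higher number beyond the scatter, with no exception among the compounds shown, and compound 1 keeps the lowest number of the series. The true size of this step stays unknown, as compound 4 is a limit and not a number: the limit of > 8 mg/kg in this assay, at which 1 of the 4 values shown sits.

The steps among compound 2, compound 3 and compound 4 cannot be read, as each joins two limits. Also open, as far as these compounds go, is how a 4-bromophenyl or 4-methylphenyl group would read in this assay, which would show whether a single group at that ring position can match the chloro.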